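Furan for chlorophenyl: cytotoxicity outlook for compound 3

The compounds below may be only part of what the source reports. "The series", "measured", "known", "first", "only" and "open" are said of these compounds alone.

The series shares one core. Compound 1 `O=[N+]([O-])c1c(CS(=O)(=O)c2ccccc2)nc2c(-c3ccccc3)cc(Cl)cn12` carries a phenyl on the fused system; in an ADME assay on HepG2 cells (Homo sapiens) for cytotoxicity, read by MTT assay, with a stated time of 72 h (on this read-out higher numbers stand for lower toxicity in this test and lower numbers for higher toxicity in this test), compound 1 returns only a limit, > 15600 nM. Compound 2 `O=[N+]([O-])c1c(CS(=O)(=O)c2ccccc2)nc2c(-c3ccc(Cl)cc3)cc(Cl)cn12` differs by chloro in place of hydrogen on an aromatic carbon. In this assay compound 2 likewise returns only a limit, > 3900 nM. The step that the two limits leave unreadable from compound 1 to compound 2 is therefore not readable, as the limit of > 15600 nM in this assay, at which 1 of the 2 values shown sits, and the limit of > 3900 nM in this assay, at which 1 of the 2 values shown sits, show. Within the data shown here, compound 2 thus stands at a limit of the test, with no number of its own, and no measured step bears on the change now considered.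

Compound 3 `O=[N+]([O-])c1c(CS(=O)(=O)c2ccccc2)nc2c(-c3ccco3)cc(Cl)cn12` carries furan-2-yl in place of 4-chlorophenyl on an aromatic carbon. With both known values sitting at limits, compound 3 is expected to give 10000 nM, in the range 3000 nM to 40000 nM, most probably again reported only as a limit. The expected step that the limit leaves unreadable from compound 2 to compound 3 is estimated to be none beyond the scatter.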

Compound 3, half-maximal cytotoxic concentration: > 3900 nM
Compound 3 ended at the assay's limit; the forecaster's own chance of this, stated with the estimate: 70%; the middle value is on the limit's open side.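

Among these compounds, compound 1, compound 2 and compound 3 all stand at limits in this assay, so no step from compound 2 to compound 3 or from compound 1 to compound 3 can be read. Left open is whether phenyl, 4-chlorophenyl and furan-2-yl differ at all on this read-out, and how far past its limit each compound lies.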